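Replacing the phenyl on the ring nitrogen with a methoxypropyl chain

The source may hold more compounds than are shown below. What is called first, only, known or untested is meant among the compounds shown, and "the series" means these compounds.

Measured compounds:
Compound 1 `CCCOCCn1c(N2CCN(C)CC2)nc2ccccc21` — 20 nM
Compound 2 `CCCCCCn1c(N2CCN(C)CC2)nc2ccccc21` — 26 nM
Compound 3 `CN1CCN(c2nc3ccccc3n2-c2ccccc2)CC1` — 760 nM

In a functional assay on ileum for inhibition of histamine H1 receptor (Cavia porcellus) (a lower number here means a stronger inhibitor, a higher number a weaker inhibitor), compound 3 gives the highest of the three numbers; compound 2 is nearest, compound 1 furthest, and both steps to it are beyond the scatter. Compound 4 `COCCCn1c(N2CCN(C)CC2)nc2ccccc21` is still to be measured. It differs from compound 3 in one place: 3-methoxypropyl in place of phenyl on an aromatic nitrogen. Among the measured compounds shown here, two measured steps bear on this change, both running toward the phenyl: a 38-fold higher number from compound 1 to compound 3 (1.58 log units; beyond the scatter) and a 29-fold higher number from compound 2 to compound 3 (1.47 log units; beyond the scatter). Between the two chains themselves the step was small, a 1.3-fold higher number from compound 1 to compound 2 (0.11 log units; within the scatter), so the shape of the chain mattered little there. Since compound 4 again carries a short chain with one oxygen on the ring nitrogen, a large step back is expected, a 25-fold lower number from compound 3 to compound 4 (1.40 log units; beyond the scatter), because compound 1 gave 20 nM and compound 2 gave 26 nM. Compound 4 is therefore estimated at 30 nM, with a range from 10 nM to 100 nM.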

Compound 4, half-maximal inhibitory concentration: 860 nM
Estimate against measurement, compound 4: 29-fold (1.46 log units) below; measured number above the stated range.
By their numbers in this assay, from the lowest: compounds 1 and 2 (each within the scatter of the next); then compounds 3 and 4 (each within the scatter of the next).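

The step of a 1.1-fold higher number from compound 3 to compound 4 (0.05 log units; within the scatter) in this assay sets 3-methoxypropyl level with phenyl on this aromatic nitrogen, so an open chain there does not by itself bring the low numbers. Methoxy in place of propyl gives a 33-fold higher number from compound 2 to compound 4 (1.52 log units; beyond the scatter) and methoxymethyl in place of propoxy gives a 43-fold higher number from compound 1 to compound 4 (1.63 log units; beyond the scatter) in this assay and, as compound 1 and compound 4 both carry a chain oxygen, its mere presence does not separate the two pairs. Nothing measured here explains this result.

The compounds shown leave open whether the sharp change follows chain length or the place of the oxygen in the chain. A pentyl chain, a 4-methoxybutyl chain or a chain ending in an amine on the same nitrogen would bear on that question.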